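This account rests on a few compounds, and the source may have more. Where it says the series, first, only, none or still open, it means among the compounds named here.

Going by the values given here, compound 2 `Fc1ccc(-c2cn3ccnc3c(-c3ccc4ncn(C5CCCCC5)c4c3)n2)cc1` shows the lowest number of the two so far in a functional assay on A549 cells (Homo sapiens) for inhibition, read by sulforhodamine B assay, with a stated time of 48 h, tested at 10 uM (on this read-out higher numbers stand for more inhibition at the one concentration tested (going by the name of the read-out) and lower numbers for less inhibition), giving 12.8%, whereas compound 1 `c1ccc(-c2cn3ccnc3c(-c3ccc4ncn(C5CCCCC5)c4c3)n2)cc1` gives 33.3%; the only measured step is a number 20.5 percentage points lower from compound 1 to compound 2 (beyond the scatter). Compound 3 `Clc1ccc(-c2cn3ccnc3c(-c3ccc4ncn(C5CCCCC5)c4c3)n2)cc1` differs from compound 2 by chloro in place of fluoro on an aromatic carbon. Among the compounds with values here, no measured pair shows chloro in place of fluoro, so the step to compound 3 cannot be read from a measured one; the fluoro step is the only guide to how a single exchange there can move the read-out. A step near the scatter in either direction, a number 3.2 percentage points higher from compound 2 to compound 3 (within the scatter), is therefore expected. Compound 3 is estimated at 16%, between 0% and 35%.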

Compound 3, a percentage reported as inhibition, at one concentration (the size of the read-out at that concentration, not a potency): 11.6%
For compound 3 the middle estimate is 4.4 percentage points above the measured one; the measured number falls inside the stated range.
By their numbers in this assay, from the lowest: compounds 3 and 2 (each within the scatter of the next); then compound 1.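

In this assay, exchanging one halogen for the other on this aromatic carbon makes no readable difference, with a number 1.2 percentage points lower from compound 2 to compound 3 (within the scatter). Chloro in place of hydrogen also lowers the number, with a number 21.7 percentage points lower from compound 1 to compound 3 (beyond the scatter), so the fall seen with fluoro is no longer a single case: both halogens at this place, para to a large group, go the same way. Nothing available explains this result. The compounds shown leave open whether only halogens lower the number here, or whether an amine or a methoxy group on the same carbon would do so too.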